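Moving Two Chlorines on a Dichlorophenyl Ring

A few compounds are considered here, and "the series" means these few. Any claim that something is new, unique, unknown or untested is made for them only; others in the source may bear on it.

Compound 1 `COc1cc(C(=O)N/N=C/c2ccc(F)c(F)c2)cc(OC)c1OC` gives 43.7% in a functional assay on PC-3 cells (Homo sapiens) for antiproliferative activity, read by MTT assay, tested at 5 uM; a higher number here means a stronger effect of the compound at the concentration tested, a lower number a weaker effect. Compound 2 `COc1cc(C2=NN(C(C)=O)C(c3c(Cl)cccc3Cl)O2)cc(OC)c1OC` gives -2.2% in this assay, the lowest of the two numbers shown, and compound 1 stands higher by a gap beyond the usual scatter. Compound 3 `COc1cc(C2=NN(C(C)=O)C(c3cc(Cl)cc(Cl)c3)O2)cc(OC)c1OC` has the same atoms as compound 2, joined differently: 3,5-dichlorophenyl in place of 2,6-dichlorophenyl on a saturated ring carbon. Among the measured compounds shown here, no step between measured compounds is available to guide this change, so the expected step of a number 7.2 percentage points higher from compound 2 to compound 3 (within the scatter) is small, in either direction, and not beyond the scatter. Compound 3 is therefore expected to give about 5% in this assay, within -10% to 25%.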

Compound 3, a percentage reported as inhibition, at one concentration (the size of the read-out at that concentration, not a potency): 93.9%
Estimate against measurement, compound 3: 88.9 percentage points below, and the stated range ends below it.
By their numbers in this assay, from the lowest: compound 2; then compound 1; then compound 3.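

In this assay, the same two chlorines on the same saturated ring carbon give a number 96.1 percentage points higher from compound 2 to compound 3 (beyond the scatter), so at this position the arrangement of the chlorines on the phenyl ring matters, not only which atoms are present. The 2,6-dichlorophenyl and 3,5-dichlorophenyl groups match in every count, so those counts cannot separate them. Nothing measured here gives a reason for the step. Still open, as far as these compounds go, is whether a single chlorine would keep this effect, and whether an amine or a carboxylic acid on the phenyl ring would.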